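Notes on the step to compound 4

The source may hold more compounds than are shown below. What is called first, only, known or untested is meant among the compounds shown, and "the series" means these compounds.

- compound 1 `O=C(/C=C/c1ccc(O)c(O)c1)N1CCN(c2ccc(F)cc2)CC1` gives 1.44 ug/mL
- compound 2 `O=C(/C=C/c1ccc(O)c(O)c1)N1CCN(c2cccc(Cl)c2)CC1` gives 1.34 ug/mL
- compound 3 `O=C(/C=C/c1ccc(O)c(O)c1)N1CCN(c2ccc([N+](=O)[O-])cc2)CC1` gives 1.14 ug/mL

All three values come from a functional assay on MCF7 cells (Homo sapiens) for antiproliferative activity, read by MTT assay, with a stated time of 48 h (a lower number here means a stronger inhibitor, a higher number a weaker inhibitor), and differ only in the group on the amine nitrogen of the shared core. Compound 3 stands level with the other two, as the measured steps show: a 1.3-fold lower number from compound 1 to compound 3 (0.10 log units; within the scatter) and a 1.2-fold lower number from compound 2 to compound 3 (0.07 log units; within the scatter). The remaining measured step is a 1.1-fold lower number from compound 1 to compound 2 (0.03 log units; within the scatter) and is of the same small size.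

The next compound is compound 4 `O=C(/C=C/c1ccc(O)c(O)c1)N1CCN(c2ccccn2)CC1`, which carries pyridin-2-yl in place of 4-nitrophenyl on an amine nitrogen in a ring. The counted difference is pyridin-2-yl in place of 4-nitrophenyl on an amine nitrogen in a ring.

All three measured steps bear on this change, since each swaps the group at this same place, and none leaves the scatter. Going by the values given here, they have a limit as a guide: no measured compound has a hetero atom in this aromatic ring, so the new ring is untested and the range is kept wide. No direction can be drawn from these steps, and no step beyond the scatter is expected in this assay. The expected step is a 1.1-fold higher number from compound 3 to compound 4 (0.06 log units; within the scatter), and it is an estimate only. For compound 4 the estimated value is 1.3 ug/mL, with an expected range from 0.7 ug/mL to 2.6 ug/mL.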

Compound 4, half-maximal inhibitory concentration: 1.82 ug/mL
For compound 4 the middle estimate is 1.4-fold (0.15 log units) below the measured one; the range from low to high includes it.
By their numbers in this assay, from the lowest: compounds 3, 2, 1 and 4 (each within the scatter of the next).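

In this assay, going by these compounds alone, the change to pyridin-2-yl puts a hetero atom into the aromatic ring on the amine nitrogen for the first time, and the three new steps are a 1.6-fold higher number from compound 3 to compound 4 (0.20 log units; within the scatter) and a 1.4-fold higher number from compound 2 to compound 4 (0.13 log units; within the scatter) and a 1.3-fold higher number from compound 1 to compound 4 (0.10 log units; within the scatter) with none of them leaving the scatter. The four groups at this place, 4-fluorophenyl, 3-chlorophenyl, 4-nitrophenyl and pyridin-2-yl, therefore cannot be told apart in this assay, so a ring with a hetero atom here has so far given no separation from the rings of carbon only. No data on the series bear on what lies behind these close values.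

Going by these compounds, it remains open whether any group at this place can move the number beyond the scatter, for example a benzyl group, an acetyl group, a short alkyl chain or a ring carrying a carboxylic acid. On these data alone, all four compounds also share the same core, so it is equally open how the number responds to a change elsewhere, such as methoxy groups in place of the two hydroxyl groups.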